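Swapping the Methoxyphenyl for a Bromophenyl Group

The compounds below may be only part of what the source reports. "The series", "measured", "known", "first", "only" and "open" are said of these compounds alone.

Compound 2 `COc1ccc(Nc2nc(-c3cccc(F)c3)nc3ccc(F)cc23)cc1` holds the lowest of the two plain numbers in a functional assay on U-937 cells (Homo sapiens) for cytotoxicity, read by MTT assay, with a stated time of 48 h (a higher number here means a weaker inhibitor, a lower number a stronger inhibitor), where compound 2 gives 41100 nM. Its nearest neighbour is compound 1 `Fc1cccc(-c2nc(Nc3ccccc3)c3cc(F)ccc3n2)c1`, which in this assay gives 45500 nM; the pair differ by a 1.1-fold lower number from compound 1 to compound 2 (0.04 log units; within the scatter). Compound 3 `Fc1cccc(-c2nc(Nc3ccc(Br)cc3)c3cc(F)ccc3n2)c1` in this assay reaches only a limit, > 50000 nM, and this is the limit of > 50000 nM in this assay, at which 1 of the 3 values shown sits.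

Compound 4 `Fc1cccc(-c2nc(Nc3ccccc3Br)c3cc(F)ccc3n2)c1` has not yet been measured. It differs from compound 2 by 2-bromophenyl in place of 4-methoxyphenyl on a nitrogen on an aromatic ring. Among the measured compounds shown here, two measured steps bear on it: an at least 1.0-fold higher number from compound 1 to compound 3 (0.04 log units; that floor lies within the scatter) and an at least 1.2-fold higher number from compound 2 to compound 3 (0.08 log units; that floor lies within the scatter), both floors that rest on the limit of compound 3. Neither gives any sign of a step beyond the scatter, though both point, if anywhere, towards a higher number.

Compound 4 is therefore expected to give about 48000 nM in this assay, with a range from 22000 nM to 100000 nM. The expected step is a 1.2-fold higher number from compound 2 to compound 4 (0.07 log units; within the scatter), and a limit rather than a number is a real possibility.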

Compound 4, half-maximal inhibitory concentration: > 50000 nM
Compound 4: a limit, no number; the forecaster's own chance of this, stated with the estimate: 45%; at least 1.0-fold (0.01 log units) between middle value and limit.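

With 2-bromophenyl on the nitrogen, compound 4 is a second compound in this assay that gives a limit and not a number, so a bromo group in either of the two places shown has so far left no plain value: the limit of > 50000 nM in this assay, at which 2 of the 4 values shown sit. Against the two plain values the result gives only floors, an at least 1.2-fold higher number from compound 2 to compound 4 (0.08 log units; that floor lies within the scatter) and an at least 1.0-fold higher number from compound 1 to compound 4 (0.04 log units; that floor lies within the scatter) and both lie within the scatter, so neither bromo compound is yet shown to differ from compound 1 or compound 2. The step between the two bromo compounds cannot be read, so moving the bromo group has no readable effect here.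

As far as these compounds go, how far compound 3 and compound 4 lie past their limits remains open. So does whether an amine or a carboxylic acid on this phenyl ring would take the number clearly below that of compound 2.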